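Trifluoromethylphenyl Variant of the Trimethoxyphenyl Oxadiazoline Series

This account rests on a few compounds, and the source may have more. Where it says the series, first, only, none or still open, it means among the compounds named here.

Within the data shown here, compound 2 `COc1cc(C2=NN(C(C)=O)C(c3ccc(Cl)c(Cl)c3)O2)cc(OC)c1OC` holds the lower of the two numbers measured so far: in a functional assay on PC-3 cells (Homo sapiens) for antiproliferative activity, read by MTT assay, tested at 5 uM (on this read-out higher numbers stand for a stronger effect at the one concentration tested and lower numbers for a weaker effect), compound 2 gives 26.1%. Among the measured compounds shown here, its nearest neighbour, compound 1 `COc1cc(C2=NN(C(C)=O)C(c3ccccc3F)O2)cc(OC)c1OC`, gives 31.6% in this assay, and the only measured step, a number 5.5 percentage points lower from compound 1 to compound 2 (within the scatter), lies within the scatter. Compound 3 `COc1cc(C2=NN(C(C)=O)C(c3cccc(C(F)(F)F)c3)O2)cc(OC)c1OC` has not yet been measured; it differs from compound 2 by 3-(trifluoromethyl)phenyl in place of 3,4-dichlorophenyl on a saturated ring carbon. For the measured compounds named here, the single step that bears on this change, a number 5.5 percentage points lower from compound 1 to compound 2 (within the scatter), exchanged one substituted phenyl group for another on the same saturated ring carbon and shifted the read-out in this assay by an amount inside the scatter, so a further exchange of this kind at the same place is expected to move the number little. Compound 3 is therefore estimated to give about 29% in this assay, between 18% and 40%. The expected step of a number 2.9 percentage points higher from compound 2 to compound 3 (within the scatter) is estimated to stay within the scatter.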

Compound 3, a percentage reported as inhibition, at one concentration (the size of the read-out at that concentration, not a potency): 43.6%
Compound 3: middle estimate off by 14.6 percentage points, on the low side, and the stated range ends below it.
By their numbers in this assay, from the lowest: compounds 2 and 1 (each within the scatter of the next); then compound 3.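

The saturated ring carbon turns out to be able to separate substituted phenyl groups in this assay and the earlier pair had given no sign of this. The exchange for 3-(trifluoromethyl)phenyl gives a number 17.5 percentage points higher from compound 2 to compound 3 (beyond the scatter) and also a number 12 percentage points higher from compound 1 to compound 3 (beyond the scatter) in the same assay. Both steps are modest, yet they set compound 3 apart from the other two compounds, and nothing at hand bears on why this group differs from 3,4-dichlorophenyl and 2-fluorophenyl.

The compounds shown leave open whether the higher number belongs to the trifluoromethyl group itself or to where it stands on the phenyl ring. They also leave open how a phenyl ring carrying an amine, a carboxylic acid or a methoxy group would read at this carbon.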